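The source may report more compounds than this note shows. Statements on the series, on what has been measured and on what is new or still open speak of the compounds shown alone.

Working notes on the series built on the shared core of compound 1 `CCn1c(C(=O)NCC(=O)OC)ccc1C(CC)(CC)c1ccc(OCS(=O)(=O)c2ccccc2)c(C)c1`. In a functional assay on MCF7 cells (Homo sapiens) for antiproliferative activity, read by MTT assay, with a stated time of 24 h (a higher number here means a weaker inhibitor, a lower number a stronger inhibitor), compound 1 reads > 50000 nM, which is a limit of the assay and not a number. Compound 2 `CCn1c(C(=O)NCCN)ccc1C(CC)(CC)c1ccc(OCS(=O)(=O)c2ccccc2)c(C)c1` gives 6470 nM. Compound 3 `CCn1c(C(=O)NC2(CO)CC2)ccc1C(CC)(CC)c1ccc(OCS(=O)(=O)c2ccccc2)c(C)c1` gives 28800 nM, the higher of the two actual numbers, with a 4.5-fold higher number from compound 2 to compound 3 (0.65 log units; beyond the scatter).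

Compound 4 `CCn1c(C(=O)N[C@H](CO)C(C)C)ccc1C(CC)(CC)c1ccc(OCS(=O)(=O)c2ccccc2)c(C)c1` is not yet measured. Its change is 1-(hydroxymethyl)-2-methylpropyl in place of 1-(hydroxymethyl)cyclopropyl on an amide-type nitrogen. Neither group carries a net charge, and the entering group has no ring.

All measured steps fall at this same amide-type nitrogen. The clear ones involve compound 2 and its 2-aminoethyl group, a group absent from compound 3 and compound 4: an at least 7.7-fold lower number from compound 1 to compound 2 (0.88 log units; beyond the scatter) and the step to compound 3 already given. The remaining step, an at least 1.7-fold lower number from compound 1 to compound 3 (0.23 log units; that floor lies within the scatter), is a floor within the scatter. Among the compounds with values here, no measured step exchanges one hydroxymethyl-bearing group for another, so the closest anchor is compound 3 at 28800 nM, and no step beyond the scatter is expected in this assay.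

The expected change is a 1.2-fold lower number from compound 3 to compound 4 (0.06 log units; within the scatter), within the scatter. The estimate for compound 4 is 25000 nM, with an expected range of 10000 nM to 50000 nM.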

Compound 4, half-maximal inhibitory concentration: 25500 nM
The estimate for compound 4 lay 1.0-fold (0.01 log units) below the measured number; low and high end bracket the measured number.
By their numbers in this assay, from the lowest: compound 2; then compounds 4 and 3 (each within the scatter of the next). At a limit, above all of these: compound 1.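

In this assay, within the data shown here, the first exchange of one hydroxymethyl-bearing group for another on the amide-type nitrogen, a 1.1-fold lower number from compound 3 to compound 4 (0.05 log units; within the scatter), stays within the scatter, so the three-membered ring of 1-(hydroxymethyl)cyclopropyl and the ringless, stereodefined 1-(hydroxymethyl)-2-methylpropyl cannot be told apart here. The step of a 3.9-fold higher number from compound 2 to compound 4 (0.60 log units; beyond the scatter) lies beyond the scatter and matches the gap already seen with compound 3, so compound 2 with its 2-aminoethyl group now stands apart from both hydroxymethyl-bearing compounds, with no compound shown going against this. The step of an at least 1.9-fold lower number from compound 1 to compound 4 (0.29 log units; that floor lies within the scatter) gives only a floor within the scatter, and the value of compound 1 is a limit of the assay and not a number: the limit of > 50000 nM in this assay, at which 1 of the 4 values shown sits.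

From the compounds shown here alone, whether a longer aminoalkyl chain, a dimethylamino group or a carboxylic acid on this amide-type nitrogen would read like compound 2 remains open. Also open are the opposite configuration of the 1-(hydroxymethyl)-2-methylpropyl group and any change elsewhere on the shared core, as all the compounds shown differ only at this nitrogen.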